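Dropping the ester from a sulfanyl-bearing phenolic amide

The source may report more compounds than this note shows. Statements on the series, on what has been measured and on what is new or still open speak of the compounds shown alone.

Compound 1 `CCOC(=O)C(CS)NC(=O)c1cc(C(C)(C)C)c(O)c(C(C)(C)C)c1` gives 23% in a functional assay, with a stated time of 30 min, tested at 50 uM (a higher number here means a stronger effect of the compound at the concentration tested, a lower number a weaker effect), the lower of the two numbers recorded; compound 2 `Cc1c(C)c2c(c(C)c1O)CCC(C)(C(=O)NCCS)O2` gives 61% in this assay, a gap beyond the usual scatter. Compound 3 `CC(C)(C)c1cc(C(=O)NCCS)cc(C(C)(C)C)c1O` is not yet measured. It differs from compound 1 by hydrogen in place of ethoxycarbonyl on a saturated chain carbon bound to an amide-type nitrogen and a saturated chain carbon. Compound 2 carries the same 2-sulfanylethyl amide and is the stronger of the pair, so a modest rise is expected, the step of a number 12 percentage points higher from compound 1 to compound 3 (beyond the scatter) being the estimated size. Compound 3 is therefore expected to give about 35%, within 15% to 60% in this assay.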

Compound 3, a percentage reported as activity, at one concentration (the size of the read-out at that concentration, not a potency): 20%
The estimate for compound 3 lay 15 percentage points above the measured number, and the stated range covers the measured number.
By their numbers in this assay, from the lowest: compounds 3 and 1 (each within the scatter of the next); then compound 2.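

In this assay, hydrogen in place of ethoxycarbonyl on this saturated chain carbon gives a number 3 percentage points lower from compound 1 to compound 3 (within the scatter), so at this position the ethoxycarbonyl can go without a difference the read-out can separate from scatter. For the compounds shown here, the earlier compounds offered no matched pair, so this is the first reading of this position. No measured evidence bears on this result. Going by these compounds, it remains open whether a carboxylic acid or an amine on the same carbon, or a longer chain in place of 2-sulfanylethyl, would give a different number.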